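Amide aryl variation on the shared core: compound 4

The compounds below may be only part of what the source reports. "The series", "measured", "known", "first", "only" and "open" are said of these compounds alone.

Compound 3 `O=C(CN1CCN(c2nnc(Cc3ccncc3)c3ccccc23)CC1)Nc1cccc(Br)c1` gives the lowest number of the three measured in a functional assay on A549 cells (Homo sapiens) for cytotoxicity, read by MTT assay, with a stated time of 72 h (a higher number here means a weaker inhibitor, a lower number a stronger inhibitor), at 1530 nM. Compound 1 `O=C(CN1CCN(c2nnc(Cc3ccncc3)c3ccccc23)CC1)Nc1ccc(F)c(F)c1` gives 3790 nM in this assay, and compound 2 `O=C(CN1CCN(c2nnc(Cc3ccncc3)c3ccccc23)CC1)Nc1ccc(F)c(Cl)c1` gives 12300 nM. The separations are a 2.5-fold lower number from compound 1 to compound 3 (0.39 log units; beyond the scatter) and an 8.0-fold lower number from compound 2 to compound 3 (0.91 log units; beyond the scatter), both beyond the scatter, so compound 3 stands clearly apart from the other two.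

Compound 4 `O=C(CN1CCN(c2nnc(Cc3ccncc3)c3ccccc23)CC1)Nc1ccc(F)c(C(F)(F)F)c1` differs from compound 3 at one place only: 4-fluoro-3-(trifluoromethyl)phenyl in place of 3-bromophenyl on an amide-type nitrogen.

Among the measured compounds shown here, two measured steps bear on this. The first is a 3.2-fold higher number from compound 1 to compound 2 (0.51 log units; beyond the scatter), which goes with chloro in place of fluoro on an aromatic carbon while the 4-fluoro is kept. The second is an 8.0-fold lower number from compound 2 to compound 3 (0.91 log units; beyond the scatter), which goes with 3-bromophenyl in place of 3-chloro-4-fluorophenyl. For the measured compounds named here, compound 4 returns to a 4-fluoro pattern, now with a trifluoromethyl where compound 2 carries chloro; no measured compound carries a trifluoromethyl, so the size of that part is untested. From these two steps a rise in the number beyond the scatter is expected, landing near where compound 2 sits or somewhat higher.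

For compound 4 the expected value in this assay is 11000 nM, within 3500 nM to 35000 nM. This corresponds to an expected step of a 7.2-fold higher number from compound 3 to compound 4 (0.86 log units; beyond the scatter).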

Compound 4, half-maximal inhibitory concentration: 16000 nM
For compound 4 the middle estimate is 1.5-fold (0.16 log units) below the measured one, and the stated range covers the measured number.
By their numbers in this assay, from the lowest: compound 3; then compound 1; then compounds 2 and 4 (each within the scatter of the next).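

In this assay, trifluoromethyl in place of chloro on the aromatic carbon gives a 1.3-fold higher number from compound 2 to compound 4 (0.11 log units; within the scatter) and so does not separate the two groups at this place, with the 4-fluoro kept in both compounds. Trifluoromethyl in place of fluoro on the same carbon gives a 4.2-fold higher number from compound 1 to compound 4 (0.63 log units; beyond the scatter) and is a step beyond the scatter, so at this carbon fluoro stands apart from both chloro and trifluoromethyl, while those two stay together. Among the compounds shown here, on the amide-type nitrogen, 4-fluoro-3-(trifluoromethyl)phenyl in place of 3-bromophenyl gives a 10-fold higher number from compound 3 to compound 4 (1.02 log units; beyond the scatter) and is the largest step so far, which leaves compound 3, the only compound here without the 4-fluoro, with the lowest number.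

The compounds shown leave open whether the low number of compound 3 goes with the bromine or with the missing 4-fluoro, and how an amine or a carboxylic acid on the aryl ring in place of the halogens would read in this assay. Nothing measured here gives a reason for any of these steps.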